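Swapping the thioether aryl group: dimethoxy to fluoro

The compounds below may be only part of what the source reports. "The series", "measured", "known", "first", "only" and "open" are said of these compounds alone.

Of the compounds shown here, three sharing one core have been measured in a functional assay on SMMC-7721 cells (Homo sapiens) for inhibition, read by CCK-8 assay, with a stated time of 72 h, tested at 8 uM; on this read-out higher numbers stand for more inhibition of growth at the one concentration tested and lower numbers for less inhibition of growth. Compound 1 `Cc1ccc(SCc2ccc(/C=C/C(=O)Nc3ccccc3N)cc2)cc1` gives 22.2%. Compound 2 `COc1ccc(SCc2ccc(/C=C/C(=O)Nc3ccccc3N)cc2)cc1OC` gives 44.6%, the highest of the three numbers; compound 3 `Nc1ccccc1NC(=O)c1ccc(CSc2ccc(Br)cc2)cc1` gives 25.3%, and the gaps from compound 2 down to compound 3 and to compound 1 both lie beyond the scatter. For the measured compounds named here, the one single-point step among the measured compounds is a number 22.4 percentage points higher from compound 1 to compound 2 (beyond the scatter), a modest rise brought about by 3,4-dimethoxyphenyl in place of 4-methylphenyl on a sulfur.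

Compound 4 `Nc1ccccc1NC(=O)/C=C/c1ccc(CSc2ccc(F)cc2)cc1` is not yet measured. It differs from compound 2 in one place: 4-fluorophenyl in place of 3,4-dimethoxyphenyl on a sulfur. The step from compound 1 to compound 2 bears directly on it, since it too exchanges the aryl group on the sulfur, and it moved the number by a modest amount when the dimethoxy group came in. Taking the dimethoxy group away again, for a 4-fluorophenyl, is therefore expected to move the number back by a comparable amount, downward; compound 3, which also carries a halogen on the aryl ring though with a different linker, sits near the level of compound 1. The expected step is a number 19.6 percentage points lower from compound 2 to compound 4 (beyond the scatter). Compound 4 is estimated at 25% in this assay, within a range from 12% to 40%.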

Compound 4, percent growth inhibition at one concentration: 15.4%
Compound 4: the middle estimate sits 9.6 percentage points above what was measured; measured number inside the range.
By their numbers in this assay, from the lowest: compounds 4, 1 and 3 (each within the scatter of the next); then compound 2.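

In this assay, the aryl group on the sulfur now has three members on the same core, and a number 29.2 percentage points lower from compound 2 to compound 4 (beyond the scatter) shows that the advantage of 3,4-dimethoxyphenyl is not confined to the comparison with 4-methylphenyl, since it also appears against 4-fluorophenyl. Fluoro in place of methyl on an aromatic carbon gives a number 6.8 percentage points lower from compound 1 to compound 4 (within the scatter), so compound 1 and compound 4 cannot be told apart in this read-out, and exchanging these two small groups on the aromatic ring makes no discernible difference at the one concentration tested. Of these three compounds, only compound 2 stands apart from the others, but no accompanying measurement bears on what lies behind this difference.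

The compounds shown leave open whether a single methoxy group on the aryl ring would retain the higher number of compound 2, or whether both methoxy groups are needed. They also leave open how an amine or a carboxylic acid on that ring, or a pyridine ring in place of the phenyl ring on the sulfur, would compare with 3,4-dimethoxyphenyl.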